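Replacing a side group of compound 2 with carboxy

The compounds below may be only part of what the source reports. "The series", "measured", "known", "first", "only" and "open" are said of these compounds alone.

Going by the values given here, in a physicochemical assay for solubility, read by nephelometry, measured as kinetic solubility, with a stated time of 30 min, at pH 2.0 (a higher number here means a more soluble compound, a lower number a less soluble compound), compound 2 `CS(=O)(=O)NC(=O)COc1ccc([C@H]2CC[C@]3(CC2)OOC2(O3)C3CC4CC(C3)CC2C4)cc1` gives 6.3 ug/mL, the only true number so far. Compound 1 `O=C(O)CNC(=O)COc1ccc([C@H]2CC[C@]3(CC2)OOC2(O3)C3CC4CC(C3)CC2C4)cc1` gives < 3.1 ug/mL, which is a limit of the assay and not a number. Compound 3 `O=C(O)c1ccc([C@H]2CC[C@]3(CC2)OOC2(O3)C3CC4CC(C3)CC2C4)cc1` carries carboxy in place of ((methylsulfonyl)carbamoyl)methoxy on an aromatic carbon. Among the compounds with values here, the one measured step, an at least 2.0-fold higher number from compound 1 to compound 2 (0.30 log units; that floor lies within the scatter), is the only guide, and it also leads away from a compound ending in carboxy. A small drop in this assay is therefore expected, with the estimated change being a 1.8-fold lower number from compound 2 to compound 3 (0.26 log units; within the scatter). For compound 3 the expected value is 3.5 ug/mL, with an estimated range of 1.5 ug/mL to 10 ug/mL.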

Compound 3, solubility: < 1.6 ug/mL
Compound 3 was reported as a limit; the forecaster's own chance of this, stated with the estimate: 50%; at least 2.1-fold (0.33 log units) between middle value and limit.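

In this assay, carboxy in place of ((methylsulfonyl)carbamoyl)methoxy on this aromatic carbon gives an at least 3.9-fold lower number from compound 2 to compound 3 (0.59 log units; beyond the scatter) and so shows that the group held here can move this read-out beyond the scatter. Compound 3 gives a limit of the assay and not a number: the limit of < 1.6 ug/mL in this assay, at which 1 of the 3 values shown sits. The step from compound 1 to compound 3 cannot be read, as both values are limits.

From the compounds shown here alone, how far compound 3 truly lies under its limit stays open. Also open, going by these compounds, is whether an amine on the same aromatic carbon would give a readable number.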